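Three Limits and a Fourth Sulfonamide

The source may hold more compounds than are shown below. What is called first, only, known or untested is meant among the compounds shown, and "the series" means these compounds.

Compound 1 `COc1ccc2c(c1)c(CC(=O)NS(=O)(=O)c1ccc(Cl)c([N+](=O)[O-])c1)c(C)n2-c1ccc(C)cc1` — > 10000 nM
Compound 2 `COc1ccc2c(c1)c(CC(=O)NS(=O)(=O)c1ccccc1)c(C)n2-c1ccc(-c2ccccc2)cc1` — > 10000 nM
Compound 3 `COc1ccc(S(=O)(=O)NC(=O)Cc2c(C)n(-c3ccc(-c4ccccc4)cc3)c3ccc(OC)cc23)cc1` — > 10000 nM

In an assay on isolated protein for binding affinity to Apoptosis regulator Bcl-2 (Homo sapiens), read by fluorescence polarization, with stated times of 30 min and 20 min (a lower number here means a stronger inhibitor, a higher number a weaker inhibitor), compound 1 gives > 10000 nM, which is a limit of the assay rather than a number. In this assay compound 2 also reaches only a limit, > 10000 nM. Compound 3 likewise returns a limit, > 10000 nM. Compound 3 therefore stands where every value shown stands, at the shared limit (the limit of > 10000 nM in this assay, at which 3 of the 3 values shown sit). Among the compounds with values here, the single step between measured compounds that differ in one place, a step that the two limits leave unreadable from compound 2 to compound 3, stays unreadable, since both of its ends are limits.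

Compound 4 `COc1ccc2c(c1)c(CC(=O)NS(=O)(=O)c1ccc(Cl)c([N+](=O)[O-])c1)c(C)n2-c1ccc(-c2ccccc2)cc1` differs from compound 3 by 4-chloro-3-nitrophenyl in place of 4-methoxyphenyl on a sulfonyl sulfur. Compound 1 already carries 4-chloro-3-nitrophenyl on its sulfonyl sulfur and sits at the limit, and compound 2, which differs from compound 4 only on the sulfonyl sulfur, sits there too. Within the data shown here, no measured step points in any direction, so no change beyond the scatter is expected from compound 3 to compound 4, and the estimated step is a step that the limit leaves unreadable from compound 3 to compound 4. Compound 4 is therefore expected to give about 15000 nM in this assay, within 5000 nM to 50000 nM, most likely reported again as a limit.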

Compound 4, inhibition constant: 720 nM
Beside the measured number, compound 4's estimate is 21-fold (1.32 log units) above it, and the stated range ends above it.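

The change on a sulfonyl sulfur can now be read: 4-chloro-3-nitrophenyl in place of 4-methoxyphenyl gives an at least 13-fold lower number from compound 3 to compound 4 (1.14 log units; beyond the scatter), and the same group in place of phenyl gives an at least 13-fold lower number from compound 2 to compound 4 (1.14 log units; beyond the scatter). This group alone does not leave the limit, however, since compound 1 also carries it; phenyl in place of methyl on an aromatic carbon gives an at least 13-fold lower number from compound 1 to compound 4 (1.14 log units; beyond the scatter). Only with both features together does a compound shown give a number, and compound 4 is the one compound off the limit: the limit of > 10000 nM in this assay, at which 3 of the 4 values shown sit.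

The compounds shown leave open whether the chloro or the nitro part of 4-chloro-3-nitrophenyl carries the step. They also leave open how 4-aminophenyl or a longer alkyl chain on the sulfonyl sulfur would read, and how far each step extends past its limit.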